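The source may report more compounds than this note shows. Statements on the series, on what has been measured and on what is new or still open speak of the compounds shown alone.

Among the measured compounds shown here, compound 3 `CC(C)N[C@H](C)C(=O)N1CCN(CCCOc2ccc(C(=O)C3CC3)cc2)CC1` sits second highest of the three numbers so far in an assay for binding affinity to histamine H2 receptor (Homo sapiens); on this read-out higher numbers stand for weaker inhibition and lower numbers for stronger inhibition. Compound 1 `CCCCCC(=O)c1ccc(OCCCN2CCN(C(=O)[C@@H](C)NC(=O)OC(C)(C)C)CC2)cc1` gives 10700 nM in this assay, and compound 2 `C[C@@H](NC(=O)OC(C)(C)C)C(=O)N1CCN(CCCOc2ccc(C(=O)C3CC3)cc2)CC1` gives 83200 nM; compound 3 itself gives 50100 nM, which is a 1.7-fold lower number from compound 2 to compound 3 (0.22 log units; within the scatter). Against compound 1 it is the far end, with a gap beyond the scatter. Compound 4 `CNCC(=O)N1CCN(CCCOc2ccc(C(=O)C3CC3)cc2)CC1` is not yet measured in this assay. Its change from compound 3 is (methylamino)methyl in place of 1-(isopropylamino)ethyl on a carbonyl carbon. For the measured compounds named here, of the two measured steps, only the one from compound 2 to compound 3 touches the same amine nitrogen, and that step was a 1.7-fold lower number from compound 2 to compound 3 (0.22 log units; within the scatter), within the scatter; the step from compound 1 to compound 2 concerns a different carbonyl carbon and was a 7.8-fold higher number from compound 1 to compound 2 (0.89 log units; beyond the scatter). Going by the values given here, since the nearest precedent on this nitrogen moved little, the expected step for compound 4 is a 1.2-fold higher number from compound 3 to compound 4 (0.08 log units; within the scatter), with no direction claimed beyond the scatter. Compound 4 is therefore estimated at 60000 nM, in a range from 20000 nM to 180000 nM.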

Compound 4, inhibition constant: 79400 nM
Estimate against measurement, compound 4: 1.3-fold (0.12 log units) below; measured number inside the range.
By their numbers in this assay, from the lowest: compound 1; then compounds 3, 4 and 2 (each within the scatter of the next).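

In this assay, putting (methylamino)methyl in place of 1-(isopropylamino)ethyl on this carbonyl carbon removes the defined stereocentre and reduces the group from 6 heavy atoms to 3, yet gives a 1.6-fold higher number from compound 3 to compound 4 (0.20 log units; within the scatter). Among the compounds shown here, replacing 1-((tert-butoxycarbonyl)amino)ethyl with the same group gives a 1.0-fold lower number from compound 2 to compound 4 (0.02 log units; within the scatter), so all three groups at this place now lie within the scatter on the shared core, whereas the earlier compounds had tested only a change on the amine nitrogen. Nothing on hand explains this flat result. Whether it also holds with the pentyl ketone of compound 1 remains open, as all three of these compounds carry the cyclopropyl ketone. Also open, going by these compounds, is how a primary amine, a carboxylic acid or a phenyl ring on this carbonyl carbon would read in this assay.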